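The source may report more compounds than this note shows. Statements on the series, on what has been measured and on what is new or still open speak of the compounds shown alone.

In an ADME assay on HT-29 cells (Homo sapiens) for cytotoxicity, read by luminescence and CellTiter-Glo, with a stated time of 12 h (a higher number here means that more compound is tolerated, a lower number that less compound is tolerated), compound 1 (`O=C(Nc1nc2ccc(Oc3ccc(F)c(NC(=O)C4(c5cccc(C(F)(F)F)c5)CC4)c3)cc2s1)C1CC1`) gives > 50000 nM, which is a limit of the assay and not a number. Compound 2 (`Cc1cccc(NC(=O)Nc2cc(Oc3ccc4nc(NC(=O)C5CC5)sc4c3)ccc2F)c1`) gives > 50000 nM, again only a limit. Compound 2 thus stands at the limit of > 50000 nM in this assay, at which 2 of the 2 values shown sit. Compound 3 (`O=C(Nc1cccc(Br)c1)Nc1cc(Oc2ccc3nc(NC(=O)C4CC4)sc3c2)ccc1F`) has bromo in place of methyl on an aromatic carbon, meta to a large group (bromo in place of methyl on an aromatic carbon). For the measured compounds named here, no pair of measured compounds shows a step. The change expected in this assay is none beyond the scatter, with an estimated a number no higher from compound 2 to compound 3 (the limit leaves the size open). Compound 3 is expected at 50000 nM, with an estimated range of 20000 nM to 100000 nM.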

Compound 3, half-maximal cytotoxic concentration: > 50000 nM
Compound 3: no number, only a limit; the forecaster's own chance of this, stated with the estimate: 85%; the middle value lies on the limit itself.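

In this assay no step can be read from compound 2 to compound 3, as both give only a limit. The compounds shown leave open where their cytotoxic concentrations lie, and whether bromo and methyl differ here at all.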